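A few compounds are considered here, and "the series" means these few. Any claim that something is new, unique, unknown or untested is made for them only; others in the source may bear on it.

In an assay on microsomes from intestine for inhibition of acyl-CoA:cholesterol acyltransferase (Oryctolagus cuniculus) (a lower number here means a stronger inhibitor, a higher number a weaker inhibitor), compound 1 `Cc1cc(C)c(NC(=O)N(Cc2cccc(-c3cc[nH]n3)c2)C2CCCCCC2)c(C)c1` gives 65 nM, and compound 2 `Cc1cc(C)c(NC(=O)N(Cc2cccc(-c3ccn(C)n3)c2)C2CCCCCC2)c(C)c1` gives 42 nM. The only measured step is a 1.5-fold lower number from compound 1 to compound 2 (0.19 log units; within the scatter); compound 2 thus holds the lowest of the two numbers shown, but is not separated from compound 1 beyond the scatter. Compound 3 `Cc1cc(C)c(NC(=O)N(Cc2cccc(-c3cnn(C)c3)c2)C2CCCCCC2)c(C)c1` differs from compound 2 by 1-methyl-1H-pyrazol-4-yl in place of 1-methyl-1H-pyrazol-3-yl on an aromatic carbon. Going by the values given here, no measured step moves the point of attachment of the 1-methyl-1H-pyrazolyl group, so the expectation rests on the unchanged remainder of the structure; the expected step is a 1.3-fold higher number from compound 2 to compound 3 (0.12 log units; within the scatter), none beyond the scatter, with wide uncertainty. For compound 3 in this assay the estimate is 55 nM, range 15 nM to 200 nM.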

Compound 3, half-maximal inhibitory concentration: 44 nM
Estimate against measurement, compound 3: 1.3-fold (0.10 log units) above; the measured number falls inside the stated range.
By their numbers in this assay, from the lowest: compounds 2, 3 and 1 (each within the scatter of the next).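

Moving the attachment point of the methylpyrazole on the aromatic carbon gives a 1.0-fold higher number from compound 2 to compound 3 (0.02 log units; within the scatter) in this assay, so 1-methyl-1H-pyrazol-3-yl and 1-methyl-1H-pyrazol-4-yl are not separated at this position. The change from 1H-pyrazol-3-yl to 1-methyl-1H-pyrazol-4-yl gives a 1.5-fold lower number from compound 1 to compound 3 (0.17 log units; within the scatter), which leaves all three compounds within the scatter of one another. No supporting data bear on why these numbers stay together. Open, on these data alone, is whether a non-pyrazole group at this position, such as a carboxylic acid or an aminomethyl group, would separate from these three compounds.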